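Swapping hydroxymethyl for formyl in compound 3

This account rests on a few compounds, and the source may have more. Where it says the series, first, only, none or still open, it means among the compounds named here.

In a functional assay on SEM cells (Homo sapiens) for cytotoxicity, with a stated time of 72 h (a higher number here means that more compound is needed for the effect, a lower number that less compound is needed), compound 1 (`C=C[C@@](C)(/C=C/c1ccc(O)cc1)CC/C=C/C(=O)c1ccccc1`) gives > 36600 nM as a limit and not a number. Compound 2 (`C=C[C@@](C)(/C=C/c1ccc(O)cc1)CC/C=C(\C)CO`) gives > 36600 nM as a limit too. Compound 3 (`C=C[C@@](C)(/C=C/c1ccc(O)c(CO)c1)CCC=C(C)C`) also gives > 36600 nM as a limit, so it has no exact number to start from. Going by the values given here, the three compounds share the limit of > 36600 nM in this assay, at which 3 of the 3 values shown sit, and offer no measured step between them.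

Compound 4 (`C=C[C@@](C)(/C=C/c1ccc(O)c(C=O)c1)CCC=C(C)C`) carries formyl in place of hydroxymethyl on an aromatic carbon, ortho to a hydroxy group (formyl in place of hydroxymethyl on an aromatic carbon).

Since compound 3 reads > 36600 nM as a limit, a readable number for compound 4 would have to lie on the lower side, meaning less compound needed. The estimate is an at least 1.6-fold lower number from compound 3 to compound 4 (0.22 log units; that floor lies within the scatter) as the expected step, though the result may well stay at the limit. In this assay the estimate for compound 4 is 22000 nM with a range of 7000 nM to 36600 nM as the expected bounds.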

Compound 4, half-maximal effective concentration: 8510 nM
For compound 4 the middle estimate is 2.6-fold (0.41 log units) above the measured one; the range from low to high includes it.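

In this assay, replacing hydroxymethyl with formyl on this aromatic carbon, ortho to a hydroxy group, gives an at least 4.3-fold lower number from compound 3 to compound 4 (0.63 log units; beyond the scatter). As far as these compounds go, compound 3 reads only as a limit, so this step is a floor and its full size remains unknown. Compound 4 shows that this position can respond to a small change, and it is the only compound shown that gives a readable number rather than sitting at the shared limit: the limit of > 36600 nM in this assay, at which 3 of the 4 values shown sit.

The compounds shown cannot separate a role for the formyl carbonyl from the loss of the hydrogen-bond donor in hydroxymethyl, a question that a methyl group, a methyl ether or a carboxylic acid on the same carbon could help answer. They also leave open whether formyl would give a readable number at another place on the aromatic ring.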